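Swapping the cyclopentyl for a protected amine chain

The compounds below may be only part of what the source reports. "The series", "measured", "known", "first", "only" and "open" are said of these compounds alone.

Compound 1, `O=C(Nc1ccc(NCC2CCCC2)cc1Cl)c1cc(Cl)ccc1O`, in an ADME assay on A549 cells (Homo sapiens) for cytotoxicity, read by resazurin assay, with a stated time of 48 h; a higher number here means that more compound is tolerated, a lower number that less compound is tolerated: 21500 nM
Compound 2, `CC(CCO)Nc1ccc(NC(=O)c2cc(Cl)ccc2O)c(Cl)c1`, in this assay: 200000 nM

Among the compounds with values here, compound 1 stands lowest of these two numbers; the one measured step, a 9.3-fold higher number from compound 1 to compound 2 (0.97 log units; beyond the scatter), is beyond the scatter. Compound 3, `CC(C)(C)OC(=O)NCCNc1ccc(NC(=O)c2cc(Cl)ccc2O)c(Cl)c1`, is not yet measured and differs from compound 1 by ((tert-butoxycarbonyl)amino)methyl in place of cyclopentyl on a saturated chain carbon bound to a nitrogen on an aromatic ring. Within the data shown here, the step from compound 1 to compound 2, where 3-hydroxy-1-methylpropyl replaced cyclopentylmethyl, is the only guide, and it raised the number. A rise of similar kind is therefore expected for compound 3, a 4.7-fold higher number from compound 1 to compound 3 (0.67 log units; beyond the scatter). Compound 3 is estimated at 100000 nM, between 30000 nM and 300000 nM.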

Compound 3, half-maximal cytotoxic concentration: 25000 nM
Compound 3: middle estimate off by 4.0-fold (0.60 log units), on the high side, outside the stated range (below it).
By their numbers in this assay, from the lowest: compounds 1 and 3 (each within the scatter of the next); then compound 2.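

Replacing cyclopentyl with ((tert-butoxycarbonyl)amino)methyl gives a 1.2-fold higher number from compound 1 to compound 3 (0.07 log units; within the scatter) in this assay and shows that this position can take a larger open chain with no clear shift in the number. A step such as a 9.3-fold higher number from compound 1 to compound 2 (0.97 log units; beyond the scatter) therefore does not follow simply from having no ring in this group. Nothing measured here explains why these two open chains differ.

As far as these compounds go, it remains open whether an amine at the end of this chain would track compound 3 or compound 2. From the compounds shown here alone, a carboxylic acid or a longer chain at this position is equally open.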